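The source may report more compounds than this note shows. Statements on the series, on what has been measured and on what is new or still open speak of the compounds shown alone.

In a functional assay on A549 cells (Homo sapiens) for antiproliferative activity, read by MTT assay, with a stated time of 48 h (a lower number here means a stronger inhibitor, a higher number a weaker inhibitor), compound 1 (`COc1cccc(N2CCN(C(=O)/C=C/c3ccc(O)c(O)c3)CC2)c1`) gives 1.27 ug/mL and compound 2 (`COc1ccc(N2CCN(C(=O)/C=C/c3ccc(O)c(O)c3)CC2)cc1`) gives 0.93 ug/mL. Among the compounds with values here, the only measured step is a 1.4-fold lower number from compound 1 to compound 2 (0.14 log units; within the scatter). Within the data shown here, compound 2 therefore stands level with the only other measured compound, not ahead of it. Compound 3 (`O=C(/C=C/c1ccc(O)c(O)c1)N1CCN(c2ccc(Cl)c(Cl)c2)CC1`) carries 3,4-dichlorophenyl in place of 4-methoxyphenyl on an amine nitrogen in a ring. The measured step only shifted the methoxy group and tested no chlorine, so it gives weak guidance, and no change beyond the scatter is expected in this assay. The expected change is a 1.1-fold higher number from compound 2 to compound 3 (0.03 log units; within the scatter). For compound 3 the estimated value is 1 ug/mL, within an expected range of 0.35 ug/mL to 3 ug/mL.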

Compound 3, half-maximal inhibitory concentration: 1.74 ug/mL
Compound 3: the middle estimate sits 1.7-fold (0.24 log units) below what was measured, and the stated range covers the measured number.
By their numbers in this assay, from the lowest: compounds 2, 1 and 3 (each within the scatter of the next).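

In this assay, 3,4-dichlorophenyl replaces each methoxyphenyl on the amine nitrogen in a ring, giving a 1.9-fold higher number from compound 2 to compound 3 (0.27 log units; within the scatter) and a 1.4-fold higher number from compound 1 to compound 3 (0.14 log units; within the scatter). Unlike the earlier shift of the methoxy group, this change puts chlorine in place of oxygen and removes the hydrogen-bond acceptor, and still no step leaves the scatter. No measurement available here accounts for these numbers. As far as these compounds go, whether a carboxylic acid or an amine on the phenyl group would give a step beyond the scatter remains open.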